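This account rests on a few compounds, and the source may have more. Where it says the series, first, only, none or still open, it means among the compounds named here.

In a functional assay on MCF7 cells (Homo sapiens) for cytotoxicity, read by MTT assay, with a stated time of 72 h (a higher number here means a weaker inhibitor, a lower number a stronger inhibitor), compound 1, `CCOC(=O)c1c(C)oc2ncnc(Nc3cccc(C)c3)c12`, gives > 1000000 nM, which is a limit of the assay and not a number. Compound 2, `Cc1cccc(Nc2ncnc3oc(C)c(CO)c23)c1`, gives 17000 nM. Compound 3, `CCOC(=O)c1c(C)oc2ncnc(Nc3ccccc3)c12`, keeps the ethoxycarbonyl of compound 1 but has hydrogen in place of methyl on an aromatic carbon. Within the data shown here, only one measured step is available, hydroxymethyl in place of ethoxycarbonyl on an aromatic carbon, and it is large. It concerns a different place in the molecule, so it sets no size for the present change. As compound 3 keeps the ethoxycarbonyl given up in an at least 58-fold lower number from compound 1 to compound 2 (1.76 log units; beyond the scatter), no step beyond the scatter is expected in this assay. For compound 3 the expected value is 1000000 nM, with an estimated range from 100000 nM to 3000000 nM. This estimate means an expected a number no higher from compound 1 to compound 3 (the limit leaves the size open).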

Compound 3, half-maximal inhibitory concentration: 851000 nM
Compound 3: the middle estimate sits 1.2-fold (0.07 log units) above what was measured, and the stated range covers the measured number.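

In this assay, among these compounds, the change from 3-methylphenyl to phenyl, made with the ethoxycarbonyl kept, gives the first reading at this position: an at least 1.1-fold lower number from compound 1 to compound 3 (0.07 log units; that floor lies within the scatter). Compound 3 therefore gives a number where compound 1 gave only a limit, but the step shows no change beyond the scatter, and its floor does not fix its true size. That size stays open because compound 1 is known only through a limit: the limit of > 1000000 nM in this assay, at which 1 of the 3 values shown sits.

The compounds shown leave open whether the methyl matters once hydroxymethyl replaces the ethoxycarbonyl, as it does in compound 2. They also leave open what a chlorine, a methoxy group or an amine would do in place of the methyl on this aromatic carbon.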